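Lactone to Imide on the Shared Core

The source may report more compounds than this note shows. Statements on the series, on what has been measured and on what is new or still open speak of the compounds shown alone.

Compound 1 `O=C1OCc2cc(N(Cc3ccc(C4CCCCC4)cn3)C(=O)[C@H]3CCN3S(=O)(=O)c3c(F)c(F)c(F)c(F)c3F)ccc21` and compound 2 `O=C([C@H]1CCN1S(=O)(=O)c1c(F)c(F)c(F)c(F)c1F)N(Cc1ccc(C2CCCCC2)cc1)c1ccc2c(=O)[nH]ccc2c1` were both examined in a functional assay on MCF7 cells (Homo sapiens) for antiproliferative activity, with a stated time of 72 h; on this read-out higher numbers stand for an effect only at larger amounts of compound and lower numbers for an effect already at smaller amounts. In this assay compound 1 gives 4600 nM, and compound 2 gives 6200 nM; the two numbers lie within the usual scatter of each other, so no order between them can be stated.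

Compound 3 `O=C1NC(=O)c2cc(N(Cc3ccc(C4CCCCC4)cn3)C(=O)[C@H]3CCN3S(=O)(=O)c3c(F)c(F)c(F)c(F)c3F)ccc21` keeps the rest of compound 1 and changes it in one place: a group of 11 heavy atoms (8 carbon, 1 nitrogen, 2 oxygen; one five-membered non-aromatic ring with 1 hetero atom, one six-membered aromatic ring of carbon only) in place of a group of 10 heavy atoms (8 carbon, 2 oxygen; one five-membered non-aromatic ring with 1 hetero atom, one six-membered aromatic ring of carbon only), on an amide-type nitrogen. The group that enters brings one hydrogen-bond donor where the leaving group had none, while the count of hydrogen-bond acceptors stays at two.

For the measured compounds named here, no measured pair in this set mirrors this change, so the size of its step is not known from data. The step from compound 1 to compound 3 is expected to be a 1.2-fold lower number from compound 1 to compound 3 (0.06 log units; within the scatter), with no direction beyond the scatter favoured. Compound 3 is estimated to give 4000 nM in this assay, within a range from 1500 nM to 12000 nM.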

Compound 3, half-maximal effective concentration: 7000 nM
The estimate for compound 3 lay 1.8-fold (0.24 log units) below the measured number; the range from low to high includes it.
By their numbers in this assay, from the lowest: compounds 1, 2 and 3 (each within the scatter of the next).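

In this assay, putting the group of 11 heavy atoms in place of the group of 10 heavy atoms on the amide-type nitrogen gives a 1.5-fold higher number from compound 1 to compound 3 (0.18 log units; within the scatter), a step that stays within the scatter. This gives a direct reading at this position, which the earlier pair could not offer: the entering group brings a hydrogen-bond donor and keeps the count of acceptors, yet no change in the number can be told from scatter. No independent measurement speaks to the reason for this result.

From the compounds shown here alone, whether a group carrying an amine or a carboxylic acid on the amide-type nitrogen would move the number beyond the scatter stays open. The single step also alters the heavy atoms and the donor count together, and the compounds shown do not separate the two.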